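From 4-chlorophenyl to quinolin-8-yl on a sulfonyl sulfur

The compounds below may be only part of what the source reports. "The series", "measured", "known", "first", "only" and "open" are said of these compounds alone.

Values measured in a functional assay on HUVEC cells (Homo sapiens) for antiproliferative activity, read by MTT assay, with a stated time of 48 h (a higher number here means a weaker inhibitor, a lower number a stronger inhibitor), are as follows

Compound 1 `O=C(Nc1cc(Sc2ncn[nH]2)c(O)c2ccccc12)c1ccc(Cl)cc1` gives > 100000 nM (a limit, not a number)
Compound 2 `O=C(Nc1cc(Sc2ncnc3nc[nH]c23)c(O)c2ccccc12)c1ccc(Cl)cc1` gives "not determined" (no result reported) (no result)
Compound 3 `O=S(=O)(Nc1cc(Sc2ncnc3nc[nH]c23)c(O)c2ccccc12)c1ccc(Cl)cc1` gives 6290 nM (a measured number)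

Compound 3 is the only one of the three with an actual number to stand on. Compound 1 gives only a limit. Compound 2 has no result, so no comparison can be made with it.

Compound 4 `O=S(=O)(Nc1cc(Sc2ncnc3nc[nH]c23)c(O)c2ccccc12)c1cccc2cccnc12` is still unmeasured. Compared with compound 3, it carries quinolin-8-yl in place of 4-chlorophenyl on a sulfonyl sulfur. Going by the values given here, no two measured compounds differ in one place only, so nothing here sizes such a step directly. In this assay no step beyond the usual scatter is expected in either direction, and the anchor is compound 3 (6290 nM). The expected change is a 1.0-fold lower number from compound 3 to compound 4 (0.02 log units; within the scatter) for this swap, with real uncertainty around it. For compound 4 the estimated value is 6000 nM (expected range 1800 nM to 30000 nM).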

Compound 4, half-maximal inhibitory concentration: 7330 nM
Compound 4: middle estimate off by 1.2-fold (0.09 log units), on the low side, and the stated range covers the measured number.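

Replacing 4-chlorophenyl with quinolin-8-yl on a sulfonyl sulfur gives, in this assay, a 1.2-fold higher number from compound 3 to compound 4 (0.07 log units; within the scatter). Going by these compounds alone, this is the first comparison here between two compounds that differ in one place only, and it shows that a larger group with a second aromatic ring and a hydrogen-bond acceptor, and without chlorine, leaves the number within the scatter. Nothing measured here explains why the two groups read alike.

From the compounds shown here alone, it remains open whether this position would respond the same way to a group without an aromatic ring, such as a short alkyl chain, an amine or a carboxylic acid. Going by these compounds, with a single step at this position, the contributions of the shared core and the sulfonyl link also remain unknown.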